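This account rests on a few compounds, and the source may have more. Where it says the series, first, only, none or still open, it means among the compounds named here.

Measured in an in vitro assay on HEK385-7 cells for displacement of a labelled ligand from prostaglandin D2 receptor 2 (Homo sapiens); a lower number here means a stronger inhibitor, a higher number a weaker inhibitor: compound 1 `O=C(O)Cc1sc(C(c2ccc(F)cc2)c2ccc(F)cc2)nc1-c1ccnc(N2CCC2)c1` gives 660 nM. Compound 2 `NS(=O)(=O)c1ccc(-c2nc(C(c3ccc(F)cc3)c3ccc(F)cc3)sc2CC(=O)O)cc1` gives 1500 nM. Compound 3 `Cc1cc(-c2nc(C(c3ccc(F)cc3)c3ccc(F)cc3)sc2CC(=O)O)ccn1` gives 3.1 nM.

Compound 3 holds the lowest number of the three, and both steps towards it, a 210-fold lower number from compound 1 to compound 3 (2.33 log units; beyond the scatter) and a 480-fold lower number from compound 2 to compound 3 (2.68 log units; beyond the scatter), lie beyond the scatter. Compound 4 `CN(C)c1cc(-c2nc(C(c3ccc(F)cc3)c3ccc(F)cc3)sc2CC(=O)O)ccn1` differs from compound 3 in one place: dimethylamino in place of methyl on an aromatic carbon. The step that bears on this is a 210-fold lower number from compound 1 to compound 3 (2.33 log units; beyond the scatter), where azetidin-1-yl gave way to methyl on an aromatic carbon of the same pyridine. Dimethylamino entering in place of methyl is the reverse kind of change, so the number for compound 4 is expected to rise, an 81-fold higher number from compound 3 to compound 4 (1.91 log units; beyond the scatter), well beyond the scatter, though perhaps not all the way back to compound 1. Compound 4 is therefore estimated at 250 nM, with a range of 40 nM to 1500 nM.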

Compound 4, half-maximal inhibitory concentration: 380 nM
Compound 4: middle estimate off by 1.5-fold (0.18 log units), on the low side, and the stated range covers the measured number.
By their numbers in this assay, from the lowest: compound 3; then compounds 4 and 1 (each within the scatter of the next); then compound 2.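

At this carbon next to the ring nitrogen, the high number of compound 1 is not peculiar to azetidin-1-yl: dimethylamino in place of methyl also gives a large rise (a 120-fold higher number from compound 3 to compound 4 (2.09 log units; beyond the scatter)). Dimethylamino and azetidin-1-yl do not separate (a 1.7-fold lower number from compound 1 to compound 4 (0.24 log units; within the scatter)). The 2-(dimethylamino)pyridin-4-yl group still gives a modestly lower number than 4-sulfamoylphenyl (a 3.9-fold lower number from compound 2 to compound 4 (0.60 log units; beyond the scatter)).

Nothing available explains these steps. Open, from the compounds shown here alone, is whether a primary amine, methylamino or methoxy at this carbon tracks methyl or dimethylamino.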